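The compounds below may be only part of what the source reports. "The series", "measured", "known", "first", "only" and "open" are said of these compounds alone.

Measured compounds:
- compound 1, `COc1ccc(CS(=O)(=O)/C=C/c2c(OC)cc(O)cc2OC)cc1[N+](=O)[O-]`, 5000 nM in a functional assay on K562 cells (Homo sapiens) for cytotoxicity, read by trypan blue exclusion, with a stated time of 96 h; on this read-out higher numbers stand for weaker inhibition and lower numbers for stronger inhibition
- compound 2, `COC(=O)CCNc1cc(CS(=O)(=O)/C=C/c2c(OC)cc(OC)cc2OC)ccc1OC`, 1000 nM in this assay

Compound 2 holds the lower of the two numbers in this assay; compound 1 gives a number that is higher by a margin beyond the usual scatter. Within the data shown here, no pair of these two compounds differs in a single place, so the two values say only where each stands, not what any one change is worth.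

Compound 3, `COc1cc(OC)c(/C=C/S(=O)(=O)Cc2ccc(OC)c(NC(C(=O)O)c3ccccc3)c2)c(OC)c1`, is not yet measured. It differs from compound 2 in one place: carboxy(phenyl)methyl in place of 2-(methoxycarbonyl)ethyl on a nitrogen on an aromatic ring. Among the measured compounds shown here, no measured step covers this exchange, so the expectation rests on compound 2 alone. The step expected from compound 2 to compound 3 in this assay is small, toward a somewhat higher number, and may not reach beyond the scatter: a 1.6-fold higher number from compound 2 to compound 3 (0.20 log units; within the scatter). Compound 3 is accordingly estimated at 1600 nM, within a range from 400 nM to 6000 nM.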

Compound 3, half-maximal inhibitory concentration: 15 nM
Estimate against measurement, compound 3: 110-fold (2.03 log units) above, and the stated range ends above it.
By their numbers in this assay, from the lowest: compound 3; then compound 2; then compound 1.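

At the nitrogen on an aromatic ring, carboxy(phenyl)methyl in place of 2-(methoxycarbonyl)ethyl gives a 67-fold lower number from compound 2 to compound 3 (1.82 log units; beyond the scatter) in this assay and so shows that this place strongly affects the read-out. Compound 1 and compound 2 differ in more than one place and could only be ranked, whereas this pair puts a measured size on one change. The exchange brings in a six-membered aromatic ring of carbon only and a hydrogen-bond donor together, and no measurement here bears on the reason for the step.

Still open, on these data alone, is which part of the entering group carries the step: the phenyl, the carboxylic acid, or the two on one carbon. A benzyl group, a carboxymethyl group or the methyl ester of carboxy(phenyl)methyl on the same nitrogen would separate these parts.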